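The source may report more compounds than this note shows. Statements on the series, on what has been measured and on what is new or still open speak of the compounds shown alone.

In a functional assay on A2780 cells (Homo sapiens) for antiproliferative activity, read by MTT assay, with a stated time of 48 h (a higher number here means a weaker inhibitor, a lower number a stronger inhibitor), compound 1 (`COc1ccc(C(=O)c2ccc(OC)c3c2C=CC(C)(C)O3)c(NC(=O)CO)c1`) gives 420 nM and compound 2 (`C=C(c1ccc(OC)cc1NC(=O)CO)c1ccc(OC)c2c1C=CC(C)(C)O2`) gives 280 nM on the same read-out. Compound 3 (`C=C(c1cc(OC)c(OC)c(OC)c1)c1ccc(OC)cc1NC(=O)CN`) gives 30 nM as the lowest number of the three, with its gaps to compound 2 and compound 1 both beyond the scatter. Compound 4 (`C=C(c1cc(OC)c(OC)c(OC)c1)c1ccc(OC)cc1NC(=O)CN(C)C`) is still unmeasured and differs from compound 3 by dimethylamino in place of amino on a saturated chain carbon bound to a carbonyl carbon in one place, with dimethylamino in place of amino on a saturated chain carbon bound to a carbonyl carbon. Among the measured compounds shown here, no measured pair isolates this change, so the expectation in this assay is a small move toward a higher number, possibly none beyond the scatter. The expected size is a 1.5-fold higher number from compound 3 to compound 4 (0.18 log units; within the scatter) on this estimate. For compound 4 the estimated value is 45 nM within a range from 14 nM to 150 nM as the expected span.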

Compound 4, half-maximal inhibitory concentration: 240 nM
Compound 4: middle estimate off by 5.3-fold (0.73 log units), on the low side; measured number outside the range, above it.
By their numbers in this assay, from the lowest: compound 3; then compounds 4, 2 and 1 (each within the scatter of the next).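

In this assay, this position proves sensitive to substitution on the amine: dimethylamino in place of amino on a saturated chain carbon bound to a carbonyl carbon gives an 8.0-fold higher number from compound 3 to compound 4 (0.90 log units; beyond the scatter). The change adds two carbons and removes the hydrogen-bond donor counted for amino, and this single pair cannot separate those two differences. No measured evidence accounts for the step.

Still open, going by these compounds, is where methylamino, carrying a single methyl on the nitrogen, would fall relative to compound 3 and compound 4. On these data alone, the response of a longer chain between the carbonyl and the amine is also open.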